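The source may hold more compounds than are shown below. What is called first, only, known or untested is meant among the compounds shown, and "the series" means these compounds.

Within the data shown here, in an ADME assay on cells (Hepatocyte, Mus musculus, strain CD-1) for pharmacokinetics, read by LC-MS, with a stated time of 3 h, tested at 1 uM (a lower number here means slower removal, a higher number faster removal of the compound), compound 1 `O=C(NCc1ccc(S(=O)(=O)c2ccccc2)cc1)N1Cc2ccncc2C1` gives 43 mL/min/kg and compound 2 `CC(C)n1cc(S(=O)(=O)c2ccc(CNC(=O)N3Cc4ccncc4C3)cc2)cn1` gives 45 mL/min/kg, so compound 2 stands within the scatter of the only other measured number. Compound 3 `O=C(NCc1ccc(S(=O)(=O)C2CCN(C3COC3)CC2)cc1)N1Cc2ccncc2C1` carries 1-(oxetan-3-yl)piperidin-4-yl in place of 1-isopropyl-1H-pyrazol-4-yl on a sulfonyl sulfur and keeps the rest of the structure of compound 2. Among the measured compounds shown here, one measured step bears on this change: a 1.0-fold higher number from compound 1 to compound 2 (0.02 log units; within the scatter) for the same sulfonyl sulfur, with 1-isopropyl-1H-pyrazol-4-yl in place of phenyl. For the measured compounds named here, both groups in that step are aromatic, and no measured compound has a non-aromatic ring at this place, so the guide is weak. No shift beyond the scatter is expected in this assay, and the expected move is a 1.1-fold lower number from compound 2 to compound 3 (0.05 log units; within the scatter) as a loose estimate. The estimated value for compound 3 is 40 mL/min/kg, with an expected range from 20 mL/min/kg to 75 mL/min/kg.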

Compound 3, clearance: 19 mL/min/kg
The estimate for compound 3 lay 2.1-fold (0.32 log units) above the measured number; the whole stated range lies above it.
By their numbers in this assay, from the lowest: compound 3; then compounds 1 and 2 (each within the scatter of the next).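

In this assay, the two aromatic groups on the sulfonyl sulfur stand within the scatter of each other, but this position is not indifferent to every group placed there. With 1-(oxetan-3-yl)piperidin-4-yl in place of 1-isopropyl-1H-pyrazol-4-yl there is a 2.4-fold lower number from compound 2 to compound 3 (0.37 log units; beyond the scatter), and with the same group in place of phenyl there is a 2.3-fold lower number from compound 1 to compound 3 (0.35 log units; beyond the scatter), so the first move beyond the scatter comes with non-aromatic rings at this place. Nothing available explains this shift, and the change cannot be assigned to either the six-membered or the four-membered ring.

Going by these compounds, it remains open whether a plain piperidin-4-yl or a 1-methylpiperidin-4-yl would match compound 3 at 19 mL/min/kg, or whether the oxetan-3-yl group is needed. A cyclohexyl or tetrahydropyran-4-yl ring would test whether the ring nitrogen matters.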